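Removing the 4-pentylphenyl group: expected effect on cell growth

The compounds below may be only part of what the source reports. "The series", "measured", "known", "first", "only" and "open" are said of these compounds alone.

Measured so far:
compound 1 `CCCCCc1ccc(-c2cn(C[C@H](O)[C@H]3OC(=O)C(OCc4ccccc4)=C3OCc3ccccc3)nn2)cc1` — 9890 nM
compound 2 `COc1ccc(-c2cn(C/C=C3\OC(=O)C(OCc4ccccc4)=C3OCc3ccccc3)nn2)cc1` — > 100000 nM

For the measured compounds named here, in a functional assay on CFPAC-1 cells (Homo sapiens) for antiproliferative activity, read by MTT assay, with a stated time of 72 h (on this read-out lower numbers stand for stronger inhibition and higher numbers for weaker inhibition), compound 1 gives 9890 nM, the only numerical value among the two compounds measured. Compound 2 sits at the limit of > 100000 nM in this assay, at which 1 of the 2 values shown sits, which is a limit of the assay and not a number. Going by the values given here, compound 2 differs from compound 1 in more than one place, so the pair shows only that compound 1 yields a number where compound 2 does not.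

Compound 3 `O=C1O[C@H]([C@@H](O)Cn2ccnn2)C(OCc2ccccc2)=C1OCc1ccccc1` has not yet been measured in this assay. Relative to compound 1 the change is hydrogen in place of 4-pentylphenyl on an aromatic carbon. Among the compounds with values here, no single-point step between measured compounds is available to calibrate this change. The step from compound 1 to compound 3 is expected to be a loss, a 3.5-fold higher number from compound 1 to compound 3 (0.55 log units; beyond the scatter), beyond the usual scatter. Compound 3 is therefore estimated at 35000 nM, with a range from 10000 nM to 120000 nM, and the value may come back as a limit.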

Compound 3, half-maximal inhibitory concentration: > 100000 nM
Compound 3 was reported as a limit; the forecaster's own chance of this, stated with the estimate: 35%; middle value at least 2.8-fold (0.45 log units) from the limit.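

In this assay compound 3 gives > 100000 nM, which is a limit of the assay and not a number. Hydrogen in place of 4-pentylphenyl on an aromatic carbon gives an at least 10-fold higher number from compound 1 to compound 3 (1.00 log units; beyond the scatter), the first step in the series that isolates a change in one place, and it shows that a measurable number in this pair depends on the 4-pentylphenyl group at this position. The true size of the step stays unknown, and the same limit recurs across the series: the limit of > 100000 nM in this assay, at which 2 of the 3 values shown sit.

The compounds shown leave open whether the phenyl ring alone or the pentyl chain carries this effect. A plain phenyl group or a longer chain such as 4-octylphenyl on the core of compound 1 would separate the two.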